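The compounds below may be only part of what the source reports. "The series", "measured", "known", "first", "only" and "open" are said of these compounds alone.

Compounds measured in a functional assay on isolated protein for agonist activity at Glucose-dependent insulinotropic receptor (Homo sapiens), read by HTRF and cAMP accumulation; on this read-out higher numbers stand for larger maximal responses and lower numbers for smaller maximal responses:
compound 1 `CC(C)OC(=O)N1CCC(O[C@H]2CC[C@H](Oc3cnc(S(C)(=O)=O)cn3)CC2)CC1` gives 110%
compound 2 `CS(=O)(=O)c1cnc(O[C@H]2CC[C@H](OC3CCN(C(=O)Oc4ccccc4)CC3)CC2)cn1` gives 116%

Compound 2 stands at the top of these two numbers, but the gap to compound 1, a number 6 percentage points higher from compound 1 to compound 2 (within the scatter), lies within the scatter, so the two cannot be told apart. Within the data shown here, that one step is the only measured comparison, and it swaps phenyl for isopropyl on an oxygen next to a carbonyl group while keeping the rest of the core.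

Compound 3 `CS(=O)(=O)c1cnc(O[C@H]2CC[C@H](OC3CCN(CC4(C(F)(F)F)CCCC4)CC3)CC2)cn1` differs from compound 2 by a group of 10 heavy atoms (7 carbon, 3 fluorine; one five-membered non-aromatic ring of carbon only) in place of a group of 9 heavy atoms (7 carbon, 2 oxygen; one six-membered aromatic ring of carbon only), on an amine nitrogen in a ring. Among the measured compounds shown here, no measured step removes the phenoxycarbonyl altogether, so the only guide is that the one change at this position, a number 6 percentage points higher from compound 1 to compound 2 (within the scatter), stayed within the scatter. On that basis compound 3 is expected to give a maximal response near those of the two measured compounds, with a step of a number 6 percentage points lower from compound 2 to compound 3 (within the scatter) that is estimated to stay within the scatter. Compound 3 is therefore estimated at 110%, between 85% and 125%.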

Compound 3, largest response reached (Emax), in percent of the reference or control that the assay uses: 37%
Compound 3: the middle estimate sits 73 percentage points above what was measured; the whole stated range lies above it.
By their numbers in this assay, from the lowest: compound 3; then compounds 1 and 2 (each within the scatter of the next).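

In this assay, the group on the amine nitrogen in a ring turns out not to be free to vary: replacing phenoxycarbonyl with the group holding a five-membered non-aromatic ring and three fluorine atoms brings a number 79 percentage points lower from compound 2 to compound 3 (beyond the scatter), and replacing the ring-free group of compound 1 brings a number 73 percentage points lower from compound 1 to compound 3 (beyond the scatter). The tolerance seen earlier thus covered only a swap on the oxygen next to a carbonyl group, and it does not extend to this change, which also removes that carbonyl group. Nothing at hand accounts for the drop.

The step changes the carbonyl group, the ring and the fluorine atoms together, so the compounds shown cannot separate their contributions. Going by these compounds, whether an amide, a urea or a benzyl group on the same nitrogen would keep the response remains open.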